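The compounds below may be only part of what the source reports. "The series", "measured", "known", "first", "only" and "open" are said of these compounds alone.

Measured so far:
compound 1 `CCCCCCCC(CCO)n1cnc2c(NC)ncnc21` — 15300 nM
compound 2 `CCCCCCCC(CCO)n1cnc2c(N)ncnc21` — > 50000 nM
compound 3 `CCCCCCCCCC(CCO)n1cnc2c(NC)ncnc21` — 4450 nM

In a functional assay on SW480 cells (Homo sapiens) for antiproliferative activity, read by MTT assay, with a stated time of 48 h (on this read-out higher numbers stand for weaker inhibition and lower numbers for stronger inhibition), compound 1 gives 15300 nM. Compound 2 sits at a limit of the assay, > 50000 nM, which is a limit and not a number (the limit of > 50000 nM in this assay, at which 1 of the 3 values shown sits). Compound 3 gives 4450 nM. From compound 2 to compound 1 the change is methyl in place of hydrogen on a nitrogen on an aromatic ring, and it made an at least 3.2-fold lower number from compound 2 to compound 1 (0.51 log units; beyond the scatter). The ethyl entering on a saturated chain carbon made a 3.4-fold lower number from compound 1 to compound 3 (0.54 log units; beyond the scatter). How the cores of compound 2 and compound 3 differ is not broken down here. Compound 4 `CCCCCCCCCC(CCO)n1cnc2c(N(C)C)ncnc21` is not yet measured in this assay. It differs from compound 3 by methyl in place of hydrogen on a nitrogen on an aromatic ring, the same kind of change as from compound 2 to compound 1, though here the nitrogen's other neighbours are aromatic carbon and saturated chain carbon rather than aromatic carbon alone. Compound 4 is expected to give 4000 nM. The expected step is a 1.1-fold lower number from compound 3 to compound 4 (0.05 log units; within the scatter), smaller than the earlier one because an at least 3.2-fold lower number from compound 2 to compound 1 (0.51 log units; beyond the scatter) arose at a nitrogen bearing two hydrogens, whereas compound 3 already carries one methyl there.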

Compound 4, half-maximal inhibitory concentration: 12200 nM
The estimate for compound 4 lay 3.1-fold (0.48 log units) below the measured number; the range from low to high includes it.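

In this assay, going from methylamino to dimethylamino gave a 2.7-fold higher number from compound 3 to compound 4 (0.44 log units; beyond the scatter), so the change did not carry over from one core to the other with the same direction: the same change on two cores in this assay, an at least 3.2-fold lower number (0.51 log units; beyond the scatter) from compound 2 to compound 1 and a 2.7-fold higher number (0.44 log units; beyond the scatter) from compound 3 to compound 4, at least 8.9-fold (0.95 log units) apart, beyond the scatter of two such steps. This rests on one pair per core and does not show whether the reversal belongs to the longer chain or to the nitrogen already bearing a methyl, as the two steps differ in both. Compound 2 gives > 50000 nM, which is a limit and not a number, so the earlier step has no exact size. Still open, from the compounds shown here alone, is how dimethylamino behaves on the shorter chain of compound 1. Also open, going by these compounds, is how an ethylamino group compares with methylamino on either chain.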